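The source may hold more compounds than are shown below. What is called first, only, known or untested is meant among the compounds shown, and "the series" means these compounds.

Three compounds share one core. Compound 1 `c1ccc(CN(CCCCN(C[C@H]2Cc3ccccc3CN2)[C@H]2CCCc3cccnc32)Cc2ccccn2)nc1` gives 664 nM in a functional assay on cells for antagonist activity at C-X-C chemokine receptor type 4 (Homo sapiens), read by fluorescence and calcium flux, with stated times of 25 min and 90 s; on this read-out lower numbers stand for stronger inhibition and higher numbers for weaker inhibition. Compound 3 `c1ccc(CNCc2ccc(CN(C[C@H]3Cc4ccccc4CN3)[C@H]3CCCc4cccnc43)cc2)nc1` gives 286 nM. Compound 2 `c1ccc2c(c1)CN[C@@H](CN(CCCCNCc1ccncc1)[C@H]1CCCc3cccnc31)C2` gives 22.7 nM, the lowest of the three numbers; compound 3 stands nearest, with a number beyond the scatter above it, and compound 1 furthest. Compound 4 `C(=C/CN(C[C@H]1Cc2ccccc2CN1)[C@H]1CCCc2cccnc21)\CNCC1CCOCC1` has not been measured. It differs from compound 2 in one place: a group of 11 heavy atoms (9 carbon, 1 nitrogen, 1 oxygen; one six-membered non-aromatic ring with 1 hetero atom) in place of a group of 11 heavy atoms (9 carbon, 2 nitrogen; one six-membered aromatic ring with 1 hetero atom), on a saturated chain carbon bound to an amine nitrogen. Going by the values given here, no measured pair shows what such a change does, so the expectation rests on the three numbers alone. A step of moderate size toward weaker inhibition is expected from compound 2 to compound 4, a 3.1-fold higher number from compound 2 to compound 4 (0.49 log units; beyond the scatter), because compound 2 at 22.7 nM stands apart from compounds 1 and 3. Compound 4 is estimated at 70 nM, within 20 nM to 250 nM.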

Compound 4, half-maximal inhibitory concentration: 24.2 nM
Beside the measured number, compound 4's estimate is 2.9-fold (0.46 log units) above it; the measured number falls inside the stated range.
By their numbers in this assay, from the lowest: compounds 2 and 4 (each within the scatter of the next); then compound 3; then compound 1.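

In this assay the change at this saturated chain carbon bound to an amine nitrogen gives a 1.1-fold higher number from compound 2 to compound 4 (0.03 log units; within the scatter) and so shows that this position tolerates the change: the pyridine ring of the 3-(((pyridin-4-yl)methyl)amino)propyl group is not needed to keep the number in this range, since a six-membered non-aromatic ring with an oxygen serves equally well. The entering group also brings a chain double bond, so two features change together. Nothing measured here explains the result. On these data alone, whether the ring change or the double bond alone would give the same number stays open. So does the outcome with a cyclohexane ring, a piperidine ring or a longer chain at this place.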